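Swapping the aryl group on an aromatic nitrogen

The source may report more compounds than this note shows. Statements on the series, on what has been measured and on what is new or still open speak of the compounds shown alone.

Three compounds share one core and differ in the group attached to an aromatic nitrogen. Among the measured compounds shown here, compound 1 `N#CC1=C(N)Oc2c(c3nc4ccccc4nc3c3ccccc23)C12C(=O)N(Cc1cnnn1-c1ccc(S(N)(=O)=O)cc1)c1ccccc12` is the first. In a functional assay on MCF7 cells (Homo sapiens) for antiproliferative activity, read by MTT assay, with a stated time of 48 h (a lower number here means a stronger inhibitor, a higher number a weaker inhibitor), compound 1 gives > 50000 nM, which is a limit of the assay rather than a number. Compound 1 therefore sits at the limit of > 50000 nM in this assay, at which 1 of the 2 values shown sits. Compound 2 `N#CC1=C(N)Oc2c(N)cc3nc4ccccc4nc3c2C12C(=O)N(Cc1cnnn1-c1ccccc1Br)c1ccccc12` is the second, and in this assay compound 2 gives 30700 nM. For the measured compounds named here, that is the only true number in this set, so compound 2 stands as the one compound with a measured value. Compound 3 `Cc1cc(C)cc(-n2nncc2CN2C(=O)C3(C(C#N)=C(N)Oc4c(N)cc5nc6ccccc6nc5c43)c3ccccc32)c1` is not yet measured; it differs from compound 2 in one place: 3,5-dimethylphenyl in place of 2-bromophenyl on an aromatic nitrogen. Going by the values given here, no measured pair shows what such a change does here. The step from compound 2 to compound 3 is expected to stay within the scatter, a 1.0-fold lower number from compound 2 to compound 3 (0.01 log units; within the scatter). Compound 3 is accordingly estimated at 30000 nM, with a range from 10000 nM to 50000 nM.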

Compound 3, half-maximal inhibitory concentration: > 50000 nM
Compound 3: only a limit was reported (the forecaster's own chance of this, stated with the estimate: 35%); at least 1.6-fold (0.22 log units) between middle value and limit.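

Among the compounds shown here, this is the first pair in the set that differs only in the aryl group on the aromatic nitrogen, and in this assay it gives an at least 1.6-fold higher number from compound 2 to compound 3 (0.21 log units; that floor lies within the scatter). On these data alone, compound 3 gives only a limit of the assay, > 50000 nM, so the true size of the step stays unknown and the step shows no sign of a stronger inhibitor with 3,5-dimethylphenyl at this position. Most of the set now rests on a limit rather than on a number: the limit of > 50000 nM in this assay, at which 2 of the 3 values shown sit.

With only 2-bromophenyl and 3,5-dimethylphenyl compared on this core, the part played by the bromine and the methyl groups cannot be separated. A plain phenyl, or a phenyl carrying an amine or a carboxylic acid, on the same nitrogen could show whether any aryl group here moves the number clearly away from the limit.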